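The source may report more compounds than this note shows. Statements on the series, on what has been measured and on what is new or still open speak of the compounds shown alone.

Three compounds share one core and differ only in the aromatic group that sits on the six-membered ring with two nitrogens. Compound 1 `CN(C)CCCCOC(=O)Nc1ccc(Cn2nc(-c3ccncc3)c3ccccc3c2=O)cc1` carries pyridin-4-yl and in an ADME assay on Huh-7 cells (Homo sapiens) for cytotoxicity, read by MTT assay, with a stated time of 48 h (a lower number here means that less compound is tolerated, a higher number that more compound is tolerated), compound 1 gives 62700 nM. Compound 2 `CN(C)CCCCOC(=O)Nc1ccc(Cn2nc(-c3ccc(C(F)(F)F)cc3)c3ccccc3c2=O)cc1` carries 4-(trifluoromethyl)phenyl and gives 3360 nM. Compound 3 `CN(C)CCCCOC(=O)Nc1ccc(Cn2nc(-c3cccc(F)c3)c3ccccc3c2=O)cc1` carries 3-fluorophenyl and gives 37400 nM, the second highest of the three numbers: a 1.7-fold lower number from compound 1 to compound 3 (0.22 log units; within the scatter), whereas an 11-fold higher number from compound 2 to compound 3 (1.05 log units; beyond the scatter) and a 19-fold lower number from compound 1 to compound 2 (1.27 log units; beyond the scatter).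

Compound 4 `COc1ccccc1-c1nn(Cc2ccc(NC(=O)OCCCCN(C)C)cc2)c(=O)c2ccccc12` is reached from compound 3 by 2-methoxyphenyl in place of 3-fluorophenyl on an aromatic carbon. All three measured steps changed this same aromatic group, and they show that such a swap can leave the number unchanged or move it by a large amount in either direction, so no firm direction can be drawn for the new group. The number for compound 4 is expected to stay close to that of compound 3, giving an estimated 1.2-fold lower number from compound 3 to compound 4 (0.10 log units; within the scatter). The estimate for compound 4 in this assay is 30000 nM, with a range from 7000 nM to 90000 nM.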

Compound 4, half-maximal cytotoxic concentration: 44800 nM
Compound 4: middle estimate off by 1.5-fold (0.17 log units), on the low side; low and high end bracket the measured number.
By their numbers in this assay, from the lowest: compound 2; then compounds 3, 4 and 1 (each within the scatter of the next).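

In this assay, 2-methoxyphenyl in place of 3-fluorophenyl gives a 1.2-fold higher number from compound 3 to compound 4 (0.08 log units; within the scatter), and in place of pyridin-4-yl it gives a 1.4-fold lower number from compound 1 to compound 4 (0.15 log units; within the scatter), so three different aromatic groups now sit together within the usual scatter. Among the compounds shown here, the oxygen and hydrogen-bond acceptor that 2-methoxyphenyl brings in therefore come with no readable change from 3-fluorophenyl, while a 13-fold higher number from compound 2 to compound 4 (1.12 log units; beyond the scatter) leaves compound 2, with 4-(trifluoromethyl)phenyl, as the only compound apart from the others. Nothing available here explains why this one group stands apart.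

Still open, as far as these compounds go, is whether the low number of compound 2 goes with the trifluoromethyl group itself or with where it sits on the phenyl ring. From the compounds shown here alone, it is also open how a phenyl ring carrying an amine or a carboxylic acid would behave at this position.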